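A few compounds are considered here, and "the series" means these few. Any claim that something is new, unique, unknown or untested is made for them only; others in the source may bear on it.

In an ADME assay on MDBK cells (Bos taurus) for cytotoxicity (on this read-out lower numbers stand for higher toxicity in this test and higher numbers for lower toxicity in this test), compound 1 `Fc1cccc(F)c1Cn1ccc2nc(-c3ccccc3)nc-2c1` gives only a limit, > 100000 nM.
In this assay compound 2 `c1ccc(Cn2ccc3nc(-c4ccccc4)nc-3c2)cc1` gives only a limit, > 100000 nM.
In this assay compound 3 `Fc1ccc(Cn2ccc3nc(-c4ccccc4)nc-3c2)cc1` gives only a limit, > 100000 nM.

Compound 2 therefore stands at the limit of this assay, as do both other measured compounds, since (the limit of > 100000 nM in this assay, at which 3 of the 3 values shown sit). The three measured steps, a step that the two limits leave unreadable from compound 1 to compound 2, a step that the two limits leave unreadable from compound 1 to compound 3 and a step that the two limits leave unreadable from compound 2 to compound 3, all run between limits and give no readable size or direction. Compound 4 `Brc1cccc(Cn2ccc3nc(-c4ccccc4)nc-3c2)c1` differs from compound 2 by bromo in place of hydrogen on an aromatic carbon. Because the step from compound 2 to compound 3 reads a step that the two limits leave unreadable from compound 2 to compound 3, a single halogen entering the same ring gives no readable change, so compound 4 is expected to show a step of a number no higher from compound 2 to compound 4 (the limit leaves the size open) and to stay at the limit. The estimated value of compound 4 is 100000 nM, in the range 50000 nM to 200000 nM.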

Compound 4, half-maximal cytotoxic concentration: 85000 nM
Estimate against measurement, compound 4: 1.2-fold (0.07 log units) above; measured number inside the range.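

Compound 4 is the only compound shown in this assay that gives a number rather than a limit, so the 3-bromophenyl group, with bromo meta to a large group, brings a readable value to this position. The steps read an at least 1.1-fold lower number from compound 2 to compound 4 (0.07 log units; that floor lies within the scatter), an at least 1.1-fold lower number from compound 3 to compound 4 (0.07 log units; that floor lies within the scatter) and an at least 1.1-fold lower number from compound 1 to compound 4 (0.07 log units; that floor lies within the scatter); each is only a floor, and none shows a change beyond the scatter. The comparison remains bounded by a limit: the limit of > 100000 nM in this assay, at which 3 of the 4 values shown sit.

The compounds shown leave open how far the number would move with an amine, a carboxylic acid or a longer chain on this ring. They also leave open whether bromo on another aromatic carbon of the ring would read the same.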